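The source may hold more compounds than are shown below. What is called first, only, known or untested is meant among the compounds shown, and "the series" means these compounds.

Series notes. Compound 1 `NS(=O)(=O)c1ccc(/N=C2\NC(=O)/C(=C3/C(=O)Nc4ccc([N+](=O)[O-])cc43)S2)cc1`, compound 2 `NS(=O)(=O)c1cccc(/N=C2\NC(=O)/C(=C3/C(=O)Nc4ccc([N+](=O)[O-])cc43)S2)c1` and compound 3 `NS(=O)(=O)c1ccc(/N=C2\NC(=O)/C(=C3/C(=O)N(Cc4ccccc4)c4ccccc43)S2)cc1` have been run in a functional assay on MCF7 cells (Homo sapiens) for antiproliferative activity, read by MTT assay; on this read-out lower numbers stand for stronger inhibition and higher numbers for weaker inhibition; compound 4 `NS(=O)(=O)c1cccc(/N=C2\NC(=O)/C(=C3/C(=O)N(Cc4ccccc4)c4ccccc43)S2)c1` has not. In this assay compound 1 gives only a limit of > 200000 nM. Compound 2 likewise returns only a limit, > 200000 nM. Compound 3 also gives only a limit, > 200000 nM. The change from compound 1 to compound 2 is 3-sulfamoylphenyl in place of 4-sulfamoylphenyl on a double-bonded nitrogen, and the step that the two limits leave unreadable from compound 1 to compound 2 cannot be sized because of the limit of > 200000 nM in this assay, at which 3 of the 3 values shown sit. How the core of compound 3 differs from that of compound 1 is not broken down here. The change from compound 3 to compound 4 is 3-sulfamoylphenyl in place of 4-sulfamoylphenyl on a double-bonded nitrogen, the same change at the same place. The expected step that the limit leaves unreadable from compound 3 to compound 4 is taken as negligible since the earlier step that the two limits leave unreadable from compound 1 to compound 2 stayed at the limit on both sides. Compound 4 is expected at 300000 nM, within 100000 nM to 1000000 nM, most likely again reported only as a limit.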

Compound 4, half-maximal inhibitory concentration: > 200000 nM
Compound 4: only a limit was reported; the forecaster's own chance of this, stated with the estimate: 85%; the middle value lies beyond the limit too.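

No step can be read from compound 3 to compound 4, because both values are limits: the limit of > 200000 nM in this assay, at which 4 of the 4 values shown sit. The compounds shown leave open whether 3-sulfamoylphenyl and 4-sulfamoylphenyl differ at all in this assay.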